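This account rests on a few compounds, and the source may have more. Where it says the series, first, only, none or still open, it means among the compounds named here.

Compounds measured so far:

Compound 1 `C/C(=N\CC1CCCCC1)c1c(O)c2ccccc2[nH]c1=O` — >= 100000 nM
Compound 2 `CCCC/N=C(\C)c1c(O)c2ccccc2[nH]c1=O` — >= 100000 nM

In an assay on isolated protein for inhibition of myosin-2 (Bos taurus), read by spectrophotometry, with a stated time of 24 min (on this read-out lower numbers stand for stronger inhibition and higher numbers for weaker inhibition), compound 1 gives >= 100000 nM, which is a limit of the assay rather than a number. In this assay compound 2 gives >= 100000 nM, also a limit. Because of that, a step that the two limits leave unreadable from compound 1 to compound 2 cannot be sized: both values rest at the limit of >= 100000 nM in this assay, at which 2 of the 2 values shown sit.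

Compound 3 `C/C(=N\CC(C)C)c1c(O)c2ccccc2[nH]c1=O` is not yet measured. It differs from compound 2 by isopropyl in place of propyl on a saturated chain carbon bound to a double-bonded nitrogen. Going by the values given here, the only measured step touching this part of the molecule is the one from compound 1 to compound 2, and its size is unreadable, so no measured guide exists for the direction or size of the change to compound 3.

With nothing pointing elsewhere, compound 3 is expected to remain at the same limit, an expected step of a number no higher from compound 2 to compound 3 (the limit leaves the size open). The estimate for compound 3 in this assay is 100000 nM, with a range from 50000 nM to 200000 nM.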

Compound 3, half-maximal inhibitory concentration: >= 100000 nM
Compound 3: a limit, no number; the forecaster's own chance of this, stated with the estimate: 85%; the middle value sits exactly at the limit.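

No step can be read among compound 1, compound 2 and compound 3 in this assay, because all three values rest at a limit rather than at a number: the limit of >= 100000 nM in this assay, at which 3 of the 3 values shown sit.

The compounds shown leave open whether swapping cyclohexyl, propyl and isopropyl changes inhibition at all.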